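The compounds below may be only part of what the source reports. "The series", "measured", "known", "first", "only" and "open" are said of these compounds alone.

The study covers compound 1 `O=C(O)c1ccc(OCc2ccccc2)cc1O`, compound 2 `O=C(NO)c1ccc(OCc2ccc(F)cc2)cc1O` and compound 3 `O=C(NCc1ccc(F)cc1)c1cccc(O)c1O`. In an ADME assay on NCI-H630 cells (Homo sapiens) for cytotoxicity, read by MTT assay, with a stated time of 72 h (on this read-out higher numbers stand for lower toxicity in this test and lower numbers for higher toxicity in this test), compound 1 reached only a limit, > 40000 nM. For compound 2 the entry in this assay reads "not determined" (no result reported). Compound 3 likewise gave only a limit in this assay, > 40000 nM. This matches (the limit of > 40000 nM in this assay, at which 2 of the 3 values shown sit), so compound 3 stands at the limit alongside compound 1, with no single number anywhere in the set. Compound 4 `O=C(NCc1ccc(F)cc1)c1cccc(OCc2ccccc2)c1O` differs from compound 3 by benzyl in place of hydrogen on an oxygen on an aromatic ring, hydroxy to benzyloxy. Going by the values given here, with no measured step to draw on, the step expected is a step that the limit leaves unreadable from compound 3 to compound 4, none beyond the scatter. Compound 4 is accordingly estimated at about 50000 nM, within 15000 nM to 150000 nM, most likely reported again as a limit.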

Compound 4, half-maximal cytotoxic concentration: > 40000 nM
Compound 4: a limit, no number (the forecaster's own chance of this, stated with the estimate: 70%); the middle value is on the limit's open side.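

In this assay compound 3 and compound 4 each give only a limit, so no step can be read between them: the limit of > 40000 nM in this assay, at which 3 of the 4 values shown sit. The compounds shown leave open whether hydroxy to benzyloxy changes the half-maximal cytotoxic concentration at all, and none of them gives a single number in this assay.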